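The compounds below may be only part of what the source reports. "The series", "measured", "known", "first", "only" and "open" are said of these compounds alone.

The compounds here share one core, shown in compound 2 `CSc1cc(C)nc(NC(=S)NC(=O)c2c(-c3ccc(Cl)cc3Cl)noc2C)n1`, and are compared in a functional assay on the whole organism (strain L.) for inhibition, with Echinochloa crus-galli as the target, with a stated time of 72 h, tested at 10 mg/L; on this read-out higher numbers stand for more inhibition of growth at the one concentration tested and lower numbers for less inhibition of growth. Compound 2 gives 27.4% and stands second among the three measured numbers: compound 3 `COc1cc(OC)n2s/c(=N\C(=O)c3c(-c4ccc(Cl)cc4Cl)noc3C)nc2n1` gives 43.2%, a higher figure, while compound 1 `Cc1cc(O)nc(NC(=S)NC(=O)c2c(-c3ccc(Cl)cc3Cl)noc2C)n1` gives -9.78%, the lowest. For the measured compounds named here, the only measured step that touches the same position is a number 37.2 percentage points higher from compound 1 to compound 2 (beyond the scatter), a large rise. Compound 4 `COc1cc(C)nc(NC(=S)NC(=O)c2c(-c3ccc(Cl)cc3Cl)noc2C)n1` differs from compound 2 by methoxy in place of methylsulfanyl on an aromatic carbon. Going by the values given here, no measured pair swaps methylsulfanyl for methoxy at this position, so the size of this change is not pinned down. That one step shows the group at this position can move the number a great deal, and compound 3, which carries methoxy groups but differs from compound 2 in more than one place, cannot be read as a one-place step. The step from compound 2 to compound 4 is therefore expected to be a moderate drop of a number 12.4 percentage points lower from compound 2 to compound 4 (beyond the scatter). Compound 4 is expected to give about 15%, with a likely range from -10% to 40%.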

Compound 4, percent growth inhibition at one concentration: 12.3%
Estimate against measurement, compound 4: 2.7 percentage points above; the range from low to high includes it.
By their numbers in this assay, from the lowest: compound 1; then compound 4; then compound 2; then compound 3.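

For the compounds shown here, replacing methylsulfanyl with methoxy on the shared core gives a number 15.1 percentage points lower from compound 2 to compound 4 (beyond the scatter) in this assay and so puts a size on this swap for the first time. Methyl in place of hydrogen on the oxygen gives a number 22.1 percentage points higher from compound 1 to compound 4 (beyond the scatter), showing that this small change on the oxygen alone moves the number upward. With the earlier hydroxy-to-methylsulfanyl step, the three groups at this position now fall into one order: hydroxy lowest, methoxy in the middle and methylsulfanyl highest. Nothing available explains this order.

The compounds shown leave open how an amine, a chlorine atom or a longer chain such as ethoxy would read at this position. They also leave open whether the same order would hold at other concentrations, since each number comes from a single test concentration.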